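This account rests on a few compounds, and the source may have more. Where it says the series, first, only, none or still open, it means among the compounds named here.

The measured compounds in a toxicity assay on HEK-293T cells (Homo sapiens) for cytotoxicity, read by CCK-8 assay, with a stated time of 48 h; on this read-out lower numbers stand for higher toxicity in this test and higher numbers for lower toxicity in this test:

Compound 1 `Cn1cc(SCc2nnc(SCc3ccccc3Cl)n2-c2c(Cl)cccc2Cl)c2ccccc21` gives 49600 nM in this assay.
Compound 2 `Cn1cc(SCc2nnc(SCc3cccc(Cl)c3F)n2-c2c(Cl)cccc2Cl)c2ccccc21` reaches only the limit of this assay, > 100000 nM.
Compound 3 `Cn1cc(SCc2nnc(SCc3ccc(Cl)cc3F)n2-c2c(Cl)cccc2Cl)c2ccccc21` gives 87300 nM in this assay.

Compound 3 holds the highest of the two numbers given; its nearest neighbour is compound 1, and the two stand within the scatter of each other, as a 1.8-fold higher number from compound 1 to compound 3 (0.25 log units; within the scatter) shows. The third value, that of compound 2, is a limit rather than a number (the limit of > 100000 nM in this assay, at which 1 of the 3 values shown sits).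

Compound 4 `Cn1cc(SCc2nnc(SCc3c(F)cccc3Cl)n2-c2c(Cl)cccc2Cl)c2ccccc21` is the next step from compound 3. The change is 2-chloro-6-fluorophenyl in place of 4-chloro-2-fluorophenyl on a saturated chain carbon bound to a sulfur. Three measured steps move chlorine and fluorine about on this same ring: an at least 2.0-fold higher number from compound 1 to compound 2 (0.30 log units; that floor lies within the scatter), a 1.8-fold higher number from compound 1 to compound 3 (0.25 log units; within the scatter) and an at least 1.1-fold lower number from compound 2 to compound 3 (0.05 log units; that floor lies within the scatter). None of them goes beyond the scatter, and all three numbers sit at the upper end of this assay. The step from compound 3 to compound 4 shifts the same two halogens once more on the same ring, so no step beyond the scatter in this assay is expected, with a slight lean towards the number of compound 1, given that compound 1 carries the chlorine at a 2-position too and gives 49600 nM. For compound 4 the expected value in this assay is 70000 nM, between 30000 nM and 140000 nM, which means an expected step of a 1.2-fold lower number from compound 3 to compound 4 (0.10 log units; within the scatter).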

Compound 4, half-maximal cytotoxic concentration: > 100000 nM
Compound 4: only a limit was reported (the forecaster's own chance of this, stated with the estimate: 30%); at least 1.4-fold (0.15 log units) between middle value and limit.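

Compound 4 returns only a limit of this assay, > 100000 nM, so the 2-chloro-6-fluorophenyl group on a saturated chain carbon bound to a sulfur gives no exact number at this position. Within the data shown here, its two readable steps are an at least 1.1-fold higher number from compound 3 to compound 4 (0.05 log units; that floor lies within the scatter) and an at least 2.0-fold higher number from compound 1 to compound 4 (0.30 log units; that floor lies within the scatter); the second is the first step here that is only fluoro in place of hydrogen on an aromatic carbon, but, as with the first, its floor stays within the scatter, so neither can be called a change beyond it. The step between compound 2 and compound 4 cannot be read, and this arrangement of the two halogens gives a second compound at the limit of this read-out: the limit of > 100000 nM in this assay, at which 2 of the 4 values shown sit.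

As far as these compounds go, how far compound 2 and compound 4 lie past that limit stays open, and so does the size of any true difference between them. From the compounds shown here alone, all four compounds carry a chlorinated phenyl ring at this position, so it also stays open how this read-out would respond to an amine, a carboxylic acid or a longer chain there.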